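The source may hold more compounds than are shown below. What is called first, only, known or untested is meant among the compounds shown, and "the series" means these compounds.

Working notes on the series. Compound 1 `Cn1c(N)c(-c2nc3ccccc3[nH]2)c2nc(C#N)c(C#N)nc21` carries the shared core with a methyl on the aromatic nitrogen; compound 2 `CN1CCN(CCn2c(N)c(-c3nc4ccccc4[nH]3)c3nc(C#N)c(C#N)nc32)CC1` and compound 3 `N#Cc1nc2c(-c3nc4ccccc4[nH]3)c(N)n(CCCO)c2nc1C#N` extend that position with a chain. Among the measured compounds shown here, in a functional assay on HL60/MX2 cells (Homo sapiens) for antiproliferative activity, read by MTT assay, with a stated time of 48 h (on this read-out lower numbers stand for stronger inhibition and higher numbers for weaker inhibition), compound 2 gives 6490 nM, the only plain number in the set. Compound 1 reaches only the limit of the assay, > 50000 nM. Compound 3 likewise sits at the limit, > 50000 nM. Two of the three values therefore stand at the limit of > 50000 nM in this assay, at which 2 of the 3 values shown sit. The readable steps are an at least 7.7-fold lower number from compound 1 to compound 2 (0.88 log units; beyond the scatter) and an at least 7.7-fold higher number from compound 2 to compound 3 (0.88 log units; beyond the scatter); the step that the two limits leave unreadable from compound 1 to compound 3 cannot be sized.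

Compound 4 `N#Cc1nc2c(-c3nc4ccccc4[nH]3)c(N)n(CCCN3CCCCC3)c2nc1C#N` is not yet measured. It differs from compound 2 by (piperidin-1-yl)methyl in place of 4-methylpiperazin-1-yl on a saturated chain carbon, two bonds along the chain from an aromatic nitrogen. Both readable steps bear on it: the gain on going to compound 2 and its loss on going to compound 3 both follow the presence of a saturated six-membered ring with a hetero atom at the chain end, which compound 4 keeps. A step within the scatter is therefore expected, a 1.4-fold lower number from compound 2 to compound 4 (0.16 log units; within the scatter). For compound 4 the expected value in this assay is 4500 nM, with a range of 1200 nM to 18000 nM.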

Compound 4, half-maximal inhibitory concentration: 1010 nM
For compound 4 the middle estimate is 4.5-fold (0.65 log units) above the measured one, and the stated range ends above it.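

In this assay the change on a saturated chain carbon, two bonds along the chain from an aromatic nitrogen, gives a 6.4-fold lower number from compound 2 to compound 4 (0.81 log units; beyond the scatter) and shows that keeping a six-membered non-aromatic ring at the chain end does not fix the value: the group carrying that ring matters too. The 3-(piperidin-1-yl)propyl chain also gives an at least 49-fold lower number from compound 3 to compound 4 (1.69 log units; beyond the scatter) and an at least 49-fold lower number from compound 1 to compound 4 (1.69 log units; beyond the scatter) in the same assay, which sets compound 4 clear of both compounds lacking such a ring. Both of these steps are only minimum sizes: the limit of > 50000 nM in this assay, at which 2 of the 4 values shown sit.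

The step from compound 2 to compound 4 alters the ring and the chain together, and the compounds shown do not separate the two. Piperidin-1-yl on the shorter chain of compound 2, 4-methylpiperazin-1-yl on the longer chain of compound 4, and morpholine at the chain end remain open.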